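Compound 1 to compound 3: working notes

This account rests on a few compounds, and the source may have more. Where it says the series, first, only, none or still open, it means among the compounds named here.

In a functional assay on MV4-11 cells (Homo sapiens) for antiproliferative activity, read by luminescence, with a stated time of 72 h (on this read-out higher numbers stand for weaker inhibition and lower numbers for stronger inhibition), compound 1 (`CC(=O)Oc1ccc(Cn2ccnc2)c2cccnc12`) gives 28500 nM, the higher of the two numbers available. The other measured member, compound 2 (`Oc1ccc(Cn2cnc3ccccc32)c2cccnc12`), gives 1000 nM, which is lower and beyond the scatter. Within the data shown here, these two compounds differ in more than one place, so no measured step isolates a single change.

The next member is compound 3 (`CC(C)(CCl)C(=O)Oc1ccc(Cn2ccnc2)c2cccnc12`). It carries 1-(chloromethyl)-1-methylethyl in place of methyl on a carbonyl carbon. Among the measured compounds shown here, with no measured precedent for this change, the expectation is loose. Since compound 1 stands high at 28500 nM, a fall seems more likely than a rise. The expected step in this assay, a 2.4-fold lower number from compound 1 to compound 3 (0.38 log units; beyond the scatter), is moderate and toward stronger inhibition, and a result within the scatter remains possible. For compound 3 the estimated value is 12000 nM, with an expected range of 3000 nM to 40000 nM.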

Compound 3, half-maximal inhibitory concentration: 8900 nM
For compound 3 the middle estimate is 1.3-fold (0.13 log units) above the measured one; measured number inside the range.
By their numbers in this assay, from the lowest: compound 2; then compound 3; then compound 1.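

In this assay, among these compounds, the replacement of methyl by 1-(chloromethyl)-1-methylethyl on a carbonyl carbon gives a 3.2-fold lower number from compound 1 to compound 3 (0.51 log units; beyond the scatter) and is the first single-place step available. The step is modest but beyond the scatter, so at this position a group of 5 heavy atoms in place of 1 goes with stronger inhibition, not weaker. No measurement shown accounts for the step, and its origin stays unassigned.

Open, on these data alone, is how the step divides between the chlorine and the added carbons, a question that a 1,1-dimethylethyl group on the same carbonyl carbon would address. Also open, as far as these compounds go, is how this assay would respond to a primary amine or a carboxylic acid in place of the chlorine.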